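The compounds below may be only part of what the source reports. "The series", "measured", "known", "first", "only" and "open" are said of these compounds alone.

In a functional assay on PC-3 cells (Homo sapiens) for inhibition, read by sulforhodamine B assay (on this read-out higher numbers stand for weaker inhibition of growth and lower numbers for stronger inhibition of growth), compound 1 `COc1ccc(-c2ccc(-c3ccc(-c4nc5ccccc5[nH]4)cc3)cc2)cc1` gives 100000 nM and holds the highest number of the three measured compounds. Compound 2 `Clc1cccc(-c2ccc(-c3ccc(-c4nc5ccccc5[nH]4)cc3)cc2)c1` gives 33700 nM and compound 3 `COc1ccc(-c2ccc(-c3ccc(-c4nc5ccccc5[nH]4)cc3)cc2)cc1OC` gives 47100 nM on the same read-out. Both stand modestly lower than compound 1, with a 3.0-fold lower number from compound 1 to compound 2 (0.47 log units; beyond the scatter) and a 2.1-fold lower number from compound 1 to compound 3 (0.33 log units; beyond the scatter) as the two steps, while a 1.4-fold higher number from compound 2 to compound 3 (0.15 log units; within the scatter) stays within the scatter.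

Compound 4 `COc1ccc(-c2ccc(-c3ccc(-c4nc5c(O)cccc5[nH]4)cc3)cc2)cc1` differs from compound 1 by hydroxy in place of hydrogen on an aromatic carbon and has hydroxy in place of hydrogen on an aromatic carbon of a six-membered aromatic ring of carbon only, part of a fused or bridged system of two rings. Among the compounds with values here, none of the measured steps alters that ring, and no measured compound carries hydroxy, so they bear on this change only indirectly. They show that the two single changes made to compound 1 each lowered the number by a modest amount. A step of similar size toward a lower number is therefore expected, although the evidence is thin and a step within the scatter would be no surprise. The estimated change is a 2.5-fold lower number from compound 1 to compound 4 (0.40 log units; beyond the scatter) and remains uncertain. Compound 4 is expected at 40000 nM with a range from 10000 nM to 100000 nM as the estimated span.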

Compound 4, concentration for 50% growth inhibition: 6610 nM
For compound 4 the middle estimate is 6.1-fold (0.78 log units) above the measured one; the whole stated range lies above it.
By their numbers in this assay, from the lowest: compound 4; then compounds 2 and 3 (each within the scatter of the next); then compound 1.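

In this assay, hydroxy in place of hydrogen on an aromatic carbon of the six-membered aromatic ring of carbon only, turning 1H-benzimidazol-2-yl into 4-hydroxy-1H-benzimidazol-2-yl, gives a large step (a 15-fold lower number from compound 1 to compound 4 (1.18 log units; beyond the scatter)). The two earlier steps from the same parent (a 3.0-fold lower number from compound 1 to compound 2 (0.47 log units; beyond the scatter); a 2.1-fold lower number from compound 1 to compound 3 (0.33 log units; beyond the scatter)) were modest and left the 1H-benzimidazol-2-yl group untouched, so this is the first change shown at this end of the molecule, and a single added oxygen here moves the number further than either change at the other end. No measurement in this account explains why this hydroxy has so large an effect.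

Open, on these data alone, is whether the hydroxy itself is required, or whether a methoxy, an amine or a fluorine on the same carbon would give a step of similar size, and whether hydroxy on the other carbons of that ring would do the same. Also open, as far as these compounds go, is whether the gain from the hydroxy would combine with the 3-chlorophenyl of compound 2 or the 3,4-dimethoxyphenyl of compound 3.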